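The compounds below may be only part of what the source reports. "The series", "measured", "known", "first", "only" and "open" are said of these compounds alone.

Measured in an ADME assay on HUVEC cells (Homo sapiens) for inhibition, read by MTT assay, with a stated time of 48 h; on this read-out lower numbers stand for stronger inhibition and higher numbers for weaker inhibition:
Compound 1 `COc1cc(/C=N/Nc2nc(-c3ccc(C(F)(F)F)cc3)cs2)c(Br)c(Br)c1OC`: > 100000 nM, a limit
Compound 2 `COc1cc(/C=N/Nc2nc(-c3ccc(F)c(F)c3)cs2)c(Br)c(Br)c1OC`: 54700 nM
Compound 3 `COc1cc(/C=N/Nc2nc(-c3ccccc3)cs2)c(Br)c(Br)c1OC`: > 100000 nM, a limit

Compound 3 stands at a limit of this assay, > 100000 nM, and is not given as a number. Compound 4 `COc1cc(/C=N/Nc2nc(-c3cccc(Br)c3)cs2)c(Br)c(Br)c1OC` has bromo in place of hydrogen on an aromatic carbon, meta to a large group: bromo in place of hydrogen on an aromatic carbon. Two measured steps change the same ring. The first is an at least 1.8-fold higher number from compound 2 to compound 3 (0.26 log units; that floor lies within the scatter). The second is a step that the two limits leave unreadable from compound 1 to compound 3. Neither supports a firm size, so in this assay only a small move to a lower number is expected, with no step beyond the scatter assured. Compound 4 is estimated at 75000 nM, with an expected range of 30000 nM to 180000 nM. The expected change is an at least 1.3-fold lower number from compound 3 to compound 4 (0.12 log units; that floor lies within the scatter).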

Compound 4, half-maximal inhibitory concentration: > 100000 nM
Compound 4: a limit, no number (the forecaster's own chance of this, stated with the estimate: 50%); middle value at least 1.3-fold (0.12 log units) from the limit.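

In this assay, compound 4 gives > 100000 nM, which is a limit and not a number. Going by these compounds alone, its steps to the other two limit compounds cannot be read, and the one readable step is an at least 1.8-fold higher number from compound 2 to compound 4 (0.26 log units; that floor lies within the scatter). Bromo at this place, meta to a large group, therefore adds no measured number, and the series gathers at one ceiling: the limit of > 100000 nM in this assay, at which 3 of the 4 values shown sit.

Going by these compounds, it remains open whether bromo here changes anything at all. On these data alone, it also remains open whether an amine or a carboxylic acid on this ring would give a measured number.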